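A few compounds are considered here, and "the series" means these few. Any claim that something is new, unique, unknown or untested is made for them only; others in the source may bear on it.

Of the compounds shown here, three sharing one core have been measured in an assay on HEK293 cells for displacement of a labelled ligand from 5-hydroxytryptamine receptor 6 (Homo sapiens), with a stated time of 60 min, tested at 1 uM, in the presence of a further agent that is not named here; on this read-out lower numbers stand for a weaker effect and higher numbers for a stronger effect at the one concentration tested. Compound 1 `COc1cc(N)c(Cl)cc1C(=O)CCC1CCN(CCNS(=O)(=O)c2ccc(N)cc2)CC1` gives 46% in this assay. Compound 2 `COc1ccc(S(=O)(=O)NCCN2CCC(CCC(=O)c3cc(Cl)c(N)cc3OC)CC2)cc1Cl` gives 85% in this assay. Compound 3 `COc1cc(N)c(Cl)cc1C(=O)CCC1CCN(CCNS(=O)(=O)c2cc(Br)c(N)c(Br)c2)CC1` gives 83% in this assay, which places it second highest of the three: it lies within the scatter of compound 2, as a number 2 percentage points lower from compound 2 to compound 3 (within the scatter) shows, and well clear of compound 1, as a number 37 percentage points higher from compound 1 to compound 3 (beyond the scatter) shows. The next step leads to compound 4 `COc1ccc(S(=O)(=O)NCCN2CCC(CCC(=O)c3cc(Cl)c(N)cc3OC)CC2)cc1`, in which (4-methoxyphenyl in place of 4-amino-3,5-dibromophenyl on a sulfonyl sulfur). Among the measured compounds shown here, two measured steps bear on this. One, a number 39 percentage points higher from compound 1 to compound 2 (beyond the scatter), shows that a 3-chloro-4-methoxyphenyl on a sulfonyl sulfur reads far higher than a 4-aminophenyl there. The other, a number 2 percentage points lower from compound 2 to compound 3 (within the scatter), shows that swapping between the two halogen-bearing rings changes nothing beyond the scatter. For the measured compounds named here, a 4-methoxyphenyl without any halogen has no measured counterpart here; compound 4 and compound 2 differ only by a chlorine, and no step for that pair is known. The step of a number 18 percentage points lower from compound 3 to compound 4 (beyond the scatter) is therefore expected to be a modest fall, carrying real uncertainty. Compound 4 is estimated at 65%, with a range from 40% to 88%.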

Compound 4, a percentage reported as inhibition, at one concentration (the size of the read-out at that concentration, not a potency): 52%
For compound 4 the middle estimate is 13 percentage points above the measured one; low and high end bracket the measured number.
By their numbers in this assay, from the lowest: compounds 1 and 4 (each within the scatter of the next); then compounds 3 and 2 (each within the scatter of the next).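

The ring on the sulfonyl sulfur depends strongly on its halogen: hydrogen in place of chloro on 3-chloro-4-methoxyphenyl gives a number 33 percentage points lower from compound 2 to compound 4 (beyond the scatter), a large step for so small a change. Without halogen, methoxy in place of amino gives a number 6 percentage points higher from compound 1 to compound 4 (within the scatter), so these two groups cannot be told apart here, while 4-methoxyphenyl in place of 4-amino-3,5-dibromophenyl gives a number 31 percentage points lower from compound 3 to compound 4 (beyond the scatter). Across these four compounds, the two rings bearing halogen read high and the two without it read low, with none going against this, but nothing available here explains that split.

On these data alone, whether a 3-bromo-4-methoxyphenyl or a 3-fluoro-4-methoxyphenyl would match the chloro ring stays open. So does whether a 3-chlorophenyl without the methoxy would keep the high reading.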